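This account rests on a few compounds, and the source may have more. Where it says the series, first, only, none or still open, it means among the compounds named here.

Working notes on the topoisomerase series. Compound 1 `NC[C@@H]1CCN(c2cc3c(cc2F)c(=O)c(C(=O)O)cn3Cc2nc(-c3ccncc3)no2)C1` was run in an assay on isolated protein for inhibition of DNA topoisomerase 1 (Homo sapiens), with a stated time of 15 min; a lower number here means a stronger inhibitor, a higher number a weaker inhibitor. In this assay compound 1 gives only a limit, > 200000 nM. That puts compound 1 at the limit of > 200000 nM in this assay, at which 1 of the 2 values shown sits, so no number is known for it. Going by the values given here, compound 2 `COc1c(N2CC[C@@H](CN)C2)c(F)cc2c(=O)c(C(=O)NO)cn(Cc3ccc(-c4ccccc4)cc3)c12` differs from compound 1 in several places at once and no single step between the two is defined; in this assay compound 2 gives 35900 nM. Among the compounds with values here, the two values show only that compound 2 returns a number where compound 1 does not.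

Compound 3 `NC[C@@H]1CCN(c2cc3c(cc2F)c(=O)c(C(=O)O)cn3Cc2ccc(-n3cccn3)cc2)C1` is the next compound for this assay. It differs from compound 1 by 4-(1H-pyrazol-1-yl)phenyl in place of 3-(pyridin-4-yl)-1,2,4-oxadiazol-5-yl on a saturated chain carbon bound to an aromatic nitrogen. Within the data shown here, no measured pair covers this change, so its size cannot be read from the data. Among the measured compounds shown here, the only pointer is compound 2, which carries a group built on a carbon-only six-membered aromatic ring on the saturated chain carbon bound to an aromatic nitrogen and gives 35900 nM. The step from compound 1 to compound 3 is expected to be an at least 1.6-fold lower number from compound 1 to compound 3 (0.22 log units; that floor lies within the scatter), a small move towards a stronger inhibitor that may still end at the limit. Compound 3 is expected at 120000 nM, within a range from 30000 nM to 400000 nM.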

Compound 3, half-maximal inhibitory concentration: 91600 nM
Estimate against measurement, compound 3: 1.3-fold (0.12 log units) above, and the stated range covers the measured number.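

With compound 3, the place on a saturated chain carbon bound to an aromatic nitrogen gives its first readable step in this assay: an at least 2.1-fold lower number from compound 1 to compound 3 (0.33 log units; beyond the scatter). This shows that, on the core of compound 1, the 4-(1H-pyrazol-1-yl)phenyl group returns a number where the 3-(pyridin-4-yl)-1,2,4-oxadiazol-5-yl group does not, and that the move lies beyond the scatter. The true size of the step stays unknown because compound 1 stands at a limit and not at a number: the limit of > 200000 nM in this assay, at which 1 of the 3 values shown sits.

The change swaps both rings at once, a six-membered aromatic ring with one hetero atom for one of carbon only and a five-membered aromatic ring with three hetero atoms for one with two, so the compounds shown cannot assign the step to either ring or to the 1,2,4-oxadiazole alone. They also leave open what a single phenyl ring, a methyl group or a longer alkyl chain would give at this place on the same core, and whether any such group comes closer to a strong inhibitor.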